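A hydroxylated six-membered ring replaces a hydroxylated five-membered ring

A few compounds are considered here, and "the series" means these few. Any claim that something is new, unique, unknown or untested is made for them only; others in the source may bear on it.

Of the compounds shown here, three sharing one core have been tested in a functional assay on the whole organism for inhibition, with Mus musculus as the target, at a dose of 30 mg/kg by the oral route; a lower number here means less inhibition, a higher number more inhibition at the dose given (going by the name of the read-out). Compound 1 `O=C(NCCCOc1ccc2nc(O)ccc2c1)N(C1CCCCC1)C1CC1` gives 100%. Compound 2 `O=C(NCCCOc1ccc2nc(O)ccc2c1)N(C1CC1)[C@@H]1CCC[C@H]1O` gives 67%, and compound 3 `O=C(NCCCOc1ccc2nc(O)ccc2c1)N(C1CCCCC1)[C@H]1CCCC[C@@H]1O` gives 57%. Among these three numbers compound 2 stands second highest; its nearest neighbour, compound 3, lies within the usual scatter of it, while compound 1 sits clearly above it: a number 33 percentage points lower from compound 1 to compound 2 (beyond the scatter) and a number 43 percentage points lower from compound 1 to compound 3 (beyond the scatter) are both large drops, each seen when a ring bearing a hydroxyl group enters on the amide-type nitrogen.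

Compound 4 `O=C(NCCCOc1ccc2nc(O)ccc2c1)N(C1CC1)[C@@H]1CCC[C@@H](O)C1` differs from compound 2 in one place: 3-hydroxycyclohexyl in place of 2-hydroxycyclopentyl on an amide-type nitrogen. The measured steps speak only to adding a hydroxyl-bearing ring, not to changing its size or moving the hydroxyl; compound 4 keeps one hydroxyl-bearing ring, as compound 2 and compound 3 do. No step shown distinguishes those two rings, so a change within the scatter is expected. Compound 4 is therefore estimated at 60% in this assay, with a range from 35% to 85%, meaning an expected step of a number 7 percentage points lower from compound 2 to compound 4 (within the scatter).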

Compound 4, a percentage reported as inhibition, in the whole organism at one dose (the size of the read-out at that dose, not a potency): 20%
Compound 4: middle estimate off by 40 percentage points, on the high side, and the stated range ends above it.
By their numbers in this assay, from the lowest: compound 4; then compounds 3 and 2 (each within the scatter of the next); then compound 1.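

In this assay, a hydroxyl-bearing ring on this amide-type nitrogen cannot be swapped freely for another: 3-hydroxycyclohexyl in place of 2-hydroxycyclopentyl gives a number 47 percentage points lower from compound 2 to compound 4 (beyond the scatter), a large step, although the ring size and the hydroxyl's position differ together. Compared with the plain cyclohexyl group, hydroxy in place of hydrogen on a saturated ring carbon gives a number 80 percentage points lower from compound 1 to compound 4 (beyond the scatter), showing that this one change is enough to bring the read-out down sharply at this dose. No measurement at hand offers an explanation for either step.

As far as these compounds go, whether ring size or hydroxyl position drives the first step remains open, since neither pair changes one of them alone. Also open, from the compounds shown here alone, is how an amine or a carboxylic acid in the hydroxyl's place would behave in this assay.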